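From Methoxy to Ethoxy: One Carbon More

The compounds below may be only part of what the source reports. "The series", "measured", "known", "first", "only" and "open" are said of these compounds alone.

Measured compounds:
compound 1, `CC(C)=CCOc1ccccc1C1CC(=O)c2ccccc2O1`, gives 41.8% in a functional assay on RAW264.7 cells (Mus musculus) for inhibition, read by immunoassay, with a stated time of 12 h, tested at 30 uM; on this read-out lower numbers stand for less inhibition and higher numbers for more inhibition at the one concentration tested (going by the name of the read-out)
compound 2, `COc1ccccc1C1CC(=O)c2ccccc2O1`, gives 37.3%

Among the compounds with values here, compound 2 stands lowest of the two numbers seen so far, but its only neighbour, compound 1, lies higher by a step within the usual scatter, so the two cannot be told apart. That single measured step, a number 4.5 percentage points lower from compound 1 to compound 2 (within the scatter), came from putting hydrogen in place of 2-methylprop-1-en-1-yl on a saturated chain carbon bound to an oxygen on an aromatic ring, and it left the read-out essentially unchanged.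

Compound 3, `CCOc1ccccc1C1CC(=O)c2ccccc2O1`, is not yet measured; it differs from compound 2 by methyl in place of hydrogen on a saturated chain carbon bound to an oxygen on an aromatic ring. This is a smaller alteration at the same place than the one already tested, so no step beyond the scatter is expected in this assay, the estimated change being a number 0.7 percentage points higher from compound 2 to compound 3 (within the scatter). Compound 3 is therefore expected to give about 38%, within a range from 26% to 50%.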

Compound 3, a percentage reported as inhibition, at one concentration (the size of the read-out at that concentration, not a potency): 29.6%
Compound 3: the middle estimate sits 8.4 percentage points above what was measured; measured number inside the range.
By their numbers in this assay, from the lowest: compounds 3, 2 and 1 (each within the scatter of the next, the first and the last beyond it).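

In this assay the change from methoxy to ethoxy gives a number 7.7 percentage points lower from compound 2 to compound 3 (within the scatter) and so cannot be told apart from no change at all. Even so, the group at this place is not without consequence: methyl in place of 2-methylprop-1-en-1-yl gives a number 12.2 percentage points lower from compound 1 to compound 3 (beyond the scatter) and is the first step at this position to stand clear of the usual variation between repeats, although only modestly. No measurement available here explains this difference.

Going by these compounds, whether a longer saturated chain such as propyl, or a chain ending in an amine or a carboxylic acid, would give a number closer to compound 3 or to compound 1 remains open. On these data alone, it is also open whether the same differences would appear at other concentrations, since each number comes from a single tested concentration.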